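Series notes: removing one methoxy group

This account rests on a few compounds, and the source may have more. Where it says the series, first, only, none or still open, it means among the compounds named here.

Compound 1 `COc1cc(-c2cc(/C=C/C(=O)c3ccc(N)cc3)[nH]n2)cc(OC)c1OC`: 9810 nM
Compound 2 `COc1ccc(-c2cc(/C=C/C(=O)c3ccc(N)cc3)[nH]n2)cc1OC`: 6300 nM
Compound 3 `COc1cc(C(=O)/C=C/c2cc(-c3cc(OC)c(OC)c(OC)c3)n[nH]2)cc(OC)c1OC`: 4220 nM

All values come from a functional assay on NCI-H522 cells (Homo sapiens) for inhibition, read by sulforhodamine B assay, with a stated time of 48 h; a higher number here means that more compound is tolerated, a lower number that less compound is tolerated. Compound 1 gives 9810 nM, while compound 2, which differs from it by hydrogen in place of methoxy on an aromatic carbon, gives 6300 nM; the step is a 1.6-fold lower number from compound 1 to compound 2 (0.19 log units; within the scatter). Compound 3 gives 4220 nM; how its core differs from the core of compound 1 is not broken down here. Compound 4 `COc1ccc(-c2cc(/C=C/C(=O)c3cc(OC)c(OC)c(OC)c3)[nH]n2)cc1OC` is not yet measured. It differs from compound 3 by hydrogen in place of methoxy on an aromatic carbon, the same change, at the same place, as from compound 1 to compound 2. Within the data shown here, the step expected here, a 1.5-fold lower number from compound 3 to compound 4 (0.18 log units; within the scatter), rests on the single earlier step of a 1.6-fold lower number from compound 1 to compound 2 (0.19 log units; within the scatter), which lies within the scatter, so no movement beyond scatter is assumed. Compound 4 is therefore estimated at 2800 nM, expected to fall between 1200 nM and 6500 nM.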

Compound 4, concentration lethal to 50% of the cells: 5390 nM
For compound 4 the middle estimate is 1.9-fold (0.28 log units) below the measured one; the range from low to high includes it.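

Hydrogen in place of methoxy on an aromatic carbon gives a 1.3-fold higher number from compound 3 to compound 4 (0.11 log units; within the scatter), so on this second core the step is again small. Set beside the earlier step, the two do not separate: the same change on two cores in this assay, a 1.6-fold lower number (0.19 log units; within the scatter) from compound 1 to compound 2 and a 1.3-fold higher number (0.11 log units; within the scatter) from compound 3 to compound 4, 2.0-fold (0.30 log units) apart, within the scatter of two such steps. In this assay the change therefore carries between these two cores without a step beyond the scatter, but two such small steps cannot show that it has a real effect on either core, nor fix its direction.

The compounds shown leave open whether a carboxylic acid or a longer alkoxy chain in place of this methoxy would give a step beyond the scatter. They also leave open how the same change behaves on any core beyond these two.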